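The compounds below may be only part of what the source reports. "The series", "measured", "known", "first", "only" and "open" are said of these compounds alone.

Of the compounds shown here, three sharing one core have been tested in a functional assay on MT4 cells (Homo sapiens) for cytotoxicity, read by MTT assay; a lower number here means that less compound is tolerated, a higher number that more compound is tolerated. Among the measured compounds shown here, compound 1 `Cc1c(O)nc(SCc2ccc(O)cc2)nc1Cc1c(Cl)cccc1Cl` is the only one with a measured number: in this assay compound 1 gives 41000 nM. Compound 2 `Cc1c(O)nc(SCc2ccc(C(C)C)cc2)nc1Cc1c(F)cccc1F` reaches only a limit of the assay, > 62000 nM. Compound 3 `COc1cc(CSc2nc(O)c(C)c(Cc3c(F)cccc3F)n2)cc(OC)c1` likewise reaches only a limit, > 60000 nM. No two of these compounds differ in just one place, so no measured step is available to guide a prediction. Compound 4 `Cc1c(O)nc(SCc2ccc(F)cc2)nc1Cc1c(Cl)cccc1Cl` is built from compound 1 by fluoro in place of hydroxy on an aromatic carbon. For the measured compounds named here, with no comparable step to lean on, the expected change is a 1.1-fold higher number from compound 1 to compound 4 (0.04 log units; within the scatter), meaning none beyond the scatter. Compound 4 is therefore estimated to give 45000 nM in this assay, within 20000 nM to 100000 nM.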

Compound 4, half-maximal cytotoxic concentration: > 61000 nM
Compound 4 gave a limit, no number; the forecaster's own chance of this, stated with the estimate: 40%; middle value at least 1.3-fold (0.13 log units) from the limit.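

Among the compounds shown here, putting fluoro in place of hydroxy on this aromatic carbon gives an at least 1.4-fold higher number from compound 1 to compound 4 (0.17 log units; that floor lies within the scatter) in this assay, the first single-place step in this set. The result for compound 4 is a limit, not a number: the limit of > 61000 nM in this assay, at which 1 of the 4 values shown sits. On these data alone, the step therefore shows no fall in the tolerated concentration when the 4-hydroxyphenyl group becomes 4-fluorophenyl, but its full size stays unknown. As far as these compounds go, how an amine or a carboxylic acid on this same aromatic carbon would read in this assay remains open.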